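Swapping a methylphenyl for pyridinyl on a dienone chain

The source may hold more compounds than are shown below. What is called first, only, known or untested is meant among the compounds shown, and "the series" means these compounds.

Measured so far in a functional assay on Hep cells (Homo sapiens) for cytotoxicity, read by sulforhodamine B assay, with a stated time of 48 h; on this read-out higher numbers stand for weaker inhibition and lower numbers for stronger inhibition:
compound 1 `CC1=C(/C=C/C(=O)/C=C/c2ccccc2)C(C)(C)CCC1` gives 62200 nM
compound 2 `CC1=C(/C=C/C(=O)/C=C/c2ccc(C#N)cc2)C(C)(C)CCC1` gives 45600 nM
compound 3 `CC1=C(/C=C/C(=O)/C=C/c2ccc(C)cc2)C(C)(C)CCC1` gives 44100 nM

All three share a core and differ only on the aromatic ring at the end of the chain. Compound 3 has the lowest of the three numbers, but the steps to it, a 1.4-fold lower number from compound 1 to compound 3 (0.15 log units; within the scatter) and a 1.0-fold lower number from compound 2 to compound 3 (0.01 log units; within the scatter), stay within the scatter, as does a 1.4-fold lower number from compound 1 to compound 2 (0.13 log units; within the scatter), so the three cannot be told apart.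

Compound 4 `CC1=C(/C=C/C(=O)/C=C/c2cccnc2)C(C)(C)CCC1` carries the change (pyridin-3-yl in place of 4-methylphenyl on a double-bonded chain carbon bound to a double-bonded chain carbon). Among the compounds with values here, none of the measured steps replaces one ring with another; they only add or swap a group on the same carbon ring, and each such swap left the number within the scatter. With the ring itself exchanged, the same small step is the most that the data support, in no particular direction. Compound 4 is therefore expected to give about 50000 nM, within 20000 nM to 125000 nM. That estimate means an expected step of a 1.1-fold higher number from compound 3 to compound 4 (0.05 log units; within the scatter).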

Compound 4, half-maximal inhibitory concentration: 45600 nM
Beside the measured number, compound 4's estimate is 1.1-fold (0.04 log units) above it, within the range that was stated.
By their numbers in this assay, from the lowest: compounds 3, 2, 4 and 1 (each within the scatter of the next).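

Exchanging the whole aromatic ring at this place on the chain, rather than a group on it, also leaves this assay without a readable change: the result is a 1.0-fold higher number from compound 3 to compound 4 (0.01 log units; within the scatter) and, against the plain phenyl ring, a 1.4-fold lower number from compound 1 to compound 4 (0.13 log units; within the scatter) in the same assay. So a ring nitrogen, which adds a hydrogen-bond acceptor to the count, can stand in for a ring carbon here with no difference that can be told from the scatter, and the four compounds still cannot be ranked. No measurement at hand speaks to why the number holds steady across these rings.

From the compounds shown here alone, whether any change at this place can move the number beyond the scatter stays open. An amine or a carboxylic acid on this ring, or a longer chain in place of the ring, would put that to the test.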